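Working notes on alpha-1B agonist activity across three analogues

This account rests on a few compounds, and the source may have more. Where it says the series, first, only, none or still open, it means among the compounds named here.

Compound 1, `c1ccc(-c2cccc3c2CCC3c2ncc[nH]2)nc1`: in a functional assay on CHO cells for agonist activity at Alpha-1B adrenergic receptor (Homo sapiens), read by FLIPR and calcium flux (a lower number here means that less compound is needed, a higher number that more compound is needed for the effect), compound 1 gives > 10000 nM, a limit.
Compound 2, `COc1c(C)ccc2c1CCC2c1ncc[nH]1`: in this assay compound 2 gives > 10000 nM, a limit.

Compound 1 stands only at the limit of > 10000 nM in this assay, at which 2 of the 2 values shown sit; no number is known for it. Compound 3, `CS(=O)(=O)Nc1cccc2c1CCC2c1ncc[nH]1`, differs from compound 1 by methanesulfonamido in place of pyridin-2-yl on an aromatic carbon. Among the measured compounds shown here, no step between measured compounds exists, and both measured values are limits, so no direction can be read from them. Compound 3 is expected to stay near the limit, estimated at 8000 nM with a range from 1500 nM to 30000 nM, which means an expected step of an at least 1.2-fold lower number from compound 1 to compound 3 (0.09 log units; that floor lies within the scatter).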

Compound 3, half-maximal effective concentration: > 10000 nM
Compound 3 gave a limit, no number; the forecaster's own chance of this, stated with the estimate: 60%; middle value at least 1.2-fold (0.09 log units) from the limit.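

Compound 1 and compound 3 both stand only at a limit, so no step between them can be read: the limit of > 10000 nM in this assay, at which 3 of the 3 values shown sit.

The compounds shown leave open whether any change on the shared core gives a readable number in this assay.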